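Carbonyl aryl swap on the unsaturated cyanopyrrole series

A few compounds are considered here, and "the series" means these few. Any claim that something is new, unique, unknown or untested is made for them only; others in the source may bear on it.

Compound 1 `CC(C)OC(=O)C1=CN(C(=O)c2cccs2)CC(C)(C)c2cc(C#N)[nH]c21` gives 16 nM in an assay on HEK293 cells for agonist activity at Bile acid receptor (Homo sapiens), read by a luciferase reporter (a lower number here means that less compound is needed, a higher number that more compound is needed for the effect), and stands lowest of the three measured numbers. Compound 2 `CC(C)OC(=O)C1CN(C(=O)c2cccc(Cl)c2)CC(C)(C)c2cc(C#N)[nH]c21` gives 1300 nM and compound 3 `CC(C)OC(=O)C1CN(C(=O)C2CCCCC2)CC(C)(C)c2cc(C#N)[nH]c21` gives 1900 nM in this assay; both differ from compound 1 in more than one place, so neither pair forms a single step against compound 1. Among the measured compounds shown here, the one single-place step measured, a 1.5-fold higher number from compound 2 to compound 3 (0.16 log units; within the scatter), exchanges the group on the carbonyl carbon and moves the number only within the scatter.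

Compound 4 `CC(C)OC(=O)C1=CN(C(=O)c2ccc(F)c(F)c2)CC(C)(C)c2cc(C#N)[nH]c21` differs from compound 1 by 3,4-difluorophenyl in place of thiophen-2-yl on a carbonyl carbon. The step from compound 2 to compound 3 bears on it only loosely, since it concerns the same carbonyl position but on a different core and with other groups; it suggests that a swap of the group on that carbonyl may leave the number roughly where it is. Compound 4 is therefore expected to give about 30 nM in this assay, in the range 8 nM to 120 nM, which means an expected step of a 1.9-fold higher number from compound 1 to compound 4 (0.27 log units; within the scatter), not clearly beyond the scatter.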

Compound 4, half-maximal effective concentration: 6.3 nM
The estimate for compound 4 lay 4.8-fold (0.68 log units) above the measured number; the measured number lies below the stated range.
By their numbers in this assay, from the lowest: compound 4; then compound 1; then compounds 2 and 3 (each within the scatter of the next).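

On the core of compound 1, the change from (thiophen-2-yl)carbonyl to (3,4-difluorophenyl)carbonyl gives a 2.5-fold lower number from compound 1 to compound 4 (0.40 log units; beyond the scatter) in this assay and so moves the number beyond the scatter, if only modestly. Among the compounds shown here, the earlier single step at this carbonyl carbon, a 1.5-fold higher number from compound 2 to compound 3 (0.16 log units; within the scatter), stayed within the scatter on a different core, so this is the first sign that the number responds to the group at this place. Nothing shown gives a reason for the step.

As far as these compounds go, whether the step comes from the change of ring or from the two fluorines remains open, and a plain phenyl on the same carbonyl would separate the two. Also open, from the compounds shown here alone, is how a group carrying an amine, such as piperidin-4-yl, would read at this place on the same core.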